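Tolerance of HepG2 Cells From Methyl to Propoxy

This account rests on a few compounds, and the source may have more. Where it says the series, first, only, none or still open, it means among the compounds named here.

Compound 1 `Cc1ccc(-c2c([N+](=O)[O-])nc3n2CC(C)O3)cc1`: > 125000 nM
Compound 2 `Cc1ccc(-c2c([N+](=O)[O-])nc3n2CC(C)O3)s1`: > 250000 nM

Both entries come from an ADME assay on HepG2 cells (Homo sapiens) for cytotoxicity, read by MTT assay, with a stated time of 24 h; a higher number here means that more compound is tolerated, a lower number that less compound is tolerated. In this assay compound 1 stands at > 125000 nM, which is a limit and not a number. Compound 2 likewise stands at > 250000 nM, also a limit. Among the measured compounds shown here, no measured step connects the two compounds, so the data offer no direct guide to the size of a structural change.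

Compound 3 `CCCOc1ccc(-c2c([N+](=O)[O-])nc3n2CC(C)O3)cc1` has propoxy in place of methyl on an aromatic carbon, para to a large group: propoxy in place of methyl on an aromatic carbon. A modest move towards less compound being tolerated is expected in this assay, not far beyond the usual scatter, and the result may again be only a limit. The expected change is an at least 1.0-fold lower number from compound 1 to compound 3 (0.01 log units; that floor lies within the scatter). For compound 3 the estimated value is 120000 nM, with an expected range from 40000 nM to 300000 nM.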

Compound 3, half-maximal cytotoxic concentration: > 62500 nM
Compound 3 ended at the assay's limit; the forecaster's own chance of this, stated with the estimate: 60%; the middle value is on the limit's open side.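

In this assay compound 3 gives > 62500 nM, a limit and not a number. Compound 1 also has only a limit, so no step can be read between compound 1 and compound 3. The compounds shown leave open whether propoxy in place of methyl changes tolerance at all.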